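Nitro for Nitrile on the Benzyl Ether

The source may report more compounds than this note shows. Statements on the series, on what has been measured and on what is new or still open speak of the compounds shown alone.

Compound 2 `N#Cc1cccc(COc2cc(O)c3c(=O)c(O)c(-c4ccccc4)oc3c2)c1` holds the higher of the two values in an ADME assay on Huh-5-2 cells (Homo sapiens) for cytotoxicity, read by WST assay, with a stated time of 3 days; on this read-out lower numbers stand for higher toxicity in this test and higher numbers for lower toxicity in this test: compound 2 gives 72000 nM, while compound 1 `N#Cc1ccccc1COc1cc(O)c2c(=O)c(O)c(-c3ccccc3)oc2c1` gives 22000 nM, the change being a 3.3-fold higher number from compound 1 to compound 2 (0.51 log units; beyond the scatter). Compound 3 `O=c1c(O)c(-c2ccccc2)oc2cc(OCc3ccc([N+](=O)[O-])cc3)cc(O)c12` carries 4-nitrophenyl in place of 3-cyanophenyl on a saturated chain carbon bound to an oxygen on an aromatic ring. Among the compounds with values here, only that one measured step touches this place, and it stayed modest; no measured pair exchanges a nitrile for a nitro group. A step within or near the scatter is therefore expected, a 1.2-fold lower number from compound 2 to compound 3 (0.08 log units; within the scatter), in either direction. Compound 3 is estimated at 60000 nM, within 25000 nM to 150000 nM.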

Compound 3, half-maximal cytotoxic concentration: 93000 nM
For compound 3 the middle estimate is 1.6-fold (0.19 log units) below the measured one, and the stated range covers the measured number.
By their numbers in this assay, from the lowest: compound 1; then compounds 2 and 3 (each within the scatter of the next).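

In this assay, 4-nitrophenyl in place of 3-cyanophenyl on a saturated chain carbon bound to an oxygen on an aromatic ring gives a 1.3-fold higher number from compound 2 to compound 3 (0.11 log units; within the scatter) and so does not separate the two groups. Set against 2-cyanophenyl, the same group gives a 4.2-fold higher number from compound 1 to compound 3 (0.63 log units; beyond the scatter) and places compound 1 apart from compound 3, as it already stood apart from compound 2. No evidence is available that accounts for either step.

The compounds shown leave open whether an amine or a carboxylic acid on this phenyl ring would stay level with compound 2 and compound 3 or fall nearer compound 1.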